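The source may hold more compounds than are shown below. What is called first, only, known or untested is meant among the compounds shown, and "the series" means these compounds.

Of the compounds shown here, three have so far been measured in an assay on isolated protein for inhibition of Rho-associated protein kinase 1 (Homo sapiens), read by mobility shift assay; on this read-out higher numbers stand for weaker inhibition and lower numbers for stronger inhibition. Compound 1 `COc1cccc([C@@H](C)NC(=O)c2ccc(-c3cn[nH]c3)c(C#N)c2)c1` gives 56 nM. Compound 2 `COc1cc(C(=O)N[C@H](C)c2ccccc2F)ccc1-c1cn[nH]c1` gives 3.1 nM, and compound 3 `COc1cc(NC(=O)[C@H](N)CCc2ccccc2)ccc1-c1cn[nH]c1` gives 7.2 nM. Compound 1 therefore stands at the highest of the three numbers, beyond the usual scatter from both of the others, with compound 3 the nearest and compound 2 the furthest. Compound 4 `COc1cccc([C@@H](C)NC(=O)c2ccc(-c3cn[nH]c3)c(C)c2)c1` remains to be measured. It differs from compound 1 in one place: methyl in place of cyano on an aromatic carbon, on an aromatic carbon of a six-membered aromatic ring of carbon only, ortho to a 1H-pyrazol-4-yl group. Among the measured compounds shown here, no measured pair shows this change, so the expectation rests on compound 1 alone. A modest step toward a lower number is expected in this assay, a 1.9-fold lower number from compound 1 to compound 4 (0.27 log units; within the scatter). Compound 4 is estimated at 30 nM, with a range from 8 nM to 110 nM.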

Compound 4, half-maximal inhibitory concentration: 8.7 nM
The estimate for compound 4 lay 3.4-fold (0.54 log units) above the measured number, within the range that was stated.
By their numbers in this assay, from the lowest: compound 2; then compounds 3 and 4 (each within the scatter of the next); then compound 1.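

In this assay, methyl in place of cyano on this aromatic carbon, ortho to a 1H-pyrazol-4-yl group, gives a 6.4-fold lower number from compound 1 to compound 4 (0.81 log units; beyond the scatter), the only single-place comparison shown here. At this position, then, the number falls beyond the scatter when the triple bond and the hydrogen-bond acceptor of the cyano group are lost. Nothing measured on these compounds accounts for the step.

As far as these compounds go, whether an amine, a chlorine or an ethyl group on this carbon would match methyl remains open. So does whether the step would hold with a different group on the amide.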